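Bromo to methoxy: a swap with little precedent

The source may report more compounds than this note shows. Statements on the series, on what has been measured and on what is new or still open speak of the compounds shown alone.

Measured in a functional assay on HepG2 cells (Homo sapiens) for inhibition, read by MTT assay, with a stated time of 48 h; on this read-out higher numbers stand for weaker inhibition of growth and lower numbers for stronger inhibition of growth:
Compound 1 `Cn1cc(C2CC(c3ccc(Cl)cc3)=NN2C(=O)c2cccnc2)c2cc(Br)ccc21`: 5800 nM
Compound 2 `Cn1cc(C2CC(c3ccc(Br)cc3)=NN2C(=O)c2cccnc2)c2cc(Br)ccc21`: 6910 nM

Among the compounds with values here, compound 2 sits level with compound 1, the only other compound measured so far. Compound 3 `COc1ccc(C2=NN(C(=O)c3cccnc3)C(c3cn(C)c4ccc(Br)cc34)C2)cc1` carries methoxy in place of bromo on an aromatic carbon, para to a large group: methoxy in place of bromo on an aromatic carbon. Within the data shown here, the one measured step, a 1.2-fold higher number from compound 1 to compound 2 (0.08 log units; within the scatter), put bromo in place of chloro. Among the measured compounds shown here, no measured step involves methoxy, so the evidence is thin, and no step beyond the scatter is expected in this assay. The estimated change is a 1.0-fold higher number from compound 2 to compound 3 (0.01 log units; within the scatter). For compound 3 the expected value is 7000 nM, with an estimated range of 3000 nM to 16000 nM.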

Compound 3, concentration for 50% growth inhibition: 540 nM
Compound 3: the middle estimate sits 13-fold (1.11 log units) above what was measured; the measured number lies below the stated range.
By their numbers in this assay, from the lowest: compound 3; then compounds 1 and 2 (each within the scatter of the next).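

Chloro and bromo at this position read alike, but methoxy does not: in this assay there is a 13-fold lower number from compound 2 to compound 3 (1.11 log units; beyond the scatter) and an 11-fold lower number from compound 1 to compound 3 (1.03 log units; beyond the scatter) as well. The position therefore responds strongly to the group it carries, and a swap between these two halogens did not reveal that. Nothing measured here explains why methoxy stands apart.

On these data alone, it remains open whether this gain is particular to methoxy or would also appear with hydroxy, ethoxy or an amine in the same place.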